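Efficacy in the shared core: from compound 3 to compound 4

The source may hold more compounds than are shown below. What is called first, only, known or untested is meant among the compounds shown, and "the series" means these compounds.

Measured so far:
compound 1 `COc1c(Cl)ccc2c1CCC2c1ncc[nH]1` — 24%
compound 2 `Cc1ccc2c(c1NS(C)(=O)=O)CCC2c1ncc[nH]1` — 83%
compound 3 `Cn1cc(-c2cccc3c2CCC3c2ncc[nH]2)cn1` — 12%

Three compounds on the shared core have been run in a functional assay on CHO cells for agonist activity at Alpha-1A adrenergic receptor (Homo sapiens), read by FLIPR and calcium flux; a lower number here means a smaller maximal response, a higher number a larger maximal response. Compound 2 gives 83%, the largest maximal response of the three. Compound 1 gives 24%. Compound 3 gives 12%, the lowest number of the set: compound 1 stands above it by a margin beyond the scatter, and compound 2 by a far larger margin, also beyond the scatter. Within the data shown here, no two measured compounds differ in a single place, so no isolated step within the measured set can be read.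

Compound 4 `CNC(=O)c1cccc2c1CCC2c1ncc[nH]1` is the next compound and has not yet been measured in this assay. It is related to compound 3 by one change: methylcarbamoyl in place of 1-methyl-1H-pyrazol-4-yl on an aromatic carbon. The group that enters brings one hydrogen-bond donor, as does the substituent of compound 2, which gave 83%; the group that leaves carried none. On that basis an upward step from compound 3 to compound 4 is expected, modest in size but beyond the scatter, with wide uncertainty. The expected step in this assay is a number 28 percentage points higher from compound 3 to compound 4 (beyond the scatter). Compound 4 is estimated at 40%, within a range of 15% to 75%.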

Compound 4, largest response reached (Emax), in percent of the reference or control that the assay uses: 59%
The estimate for compound 4 lay 19 percentage points below the measured number; the measured number falls inside the stated range.
By their numbers in this assay, from the lowest: compound 3; then compound 1; then compound 4; then compound 2.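

In this assay, among these compounds, the exchange of 1-methyl-1H-pyrazol-4-yl for methylcarbamoyl on this aromatic carbon gives a number 47 percentage points higher from compound 3 to compound 4 (beyond the scatter) and is the first single-place step that can be read, a large one. The maximal response is therefore not set by the shared core alone: at this position it moves strongly with the substituent, and a group without a ring, carrying a hydrogen-bond donor, stands on the higher side of the step. Among the compounds shown here, nothing measured so far gives a reason for this step, so it stands as an observation only.

The compounds shown leave open which part of methylcarbamoyl goes with the higher response, a question that carbamoyl without the methyl, dimethylcarbamoyl, a carboxylic acid or an aminomethyl group on the same aromatic carbon would address. They also leave open whether the step depends on the amide itself or on the loss of the five-membered aromatic ring, which a simple methyl or a methoxy group at this place could help separate.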